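A few compounds are considered here, and "the series" means these few. Any claim that something is new, unique, unknown or untested is made for them only; others in the source may bear on it.

Working notes on the series. Compound 1 `CCNC(=O)C1=Cc2ccc(OC)cc2OC1c1cc(OC)c(OC)c(OC)c1` gives in a functional assay for inhibition of nuclear factor NF-kappa-B complex (Homo sapiens) (a lower number here means a stronger inhibitor, a higher number a weaker inhibitor), only a limit, > 50000 nM. For the measured compounds named here, compound 2 `COC(=O)C1=Cc2ccc(OC)cc2OC1c1cc(OC)c(OC)c(OC)c1` gives in this assay the value 13800 nM, the only actual number in the set. Going by the values given here, the step of an at least 3.6-fold lower number from compound 1 to compound 2 (0.55 log units; beyond the scatter) is the single measured comparison, and its size is bounded by the limit of > 50000 nM in this assay, at which 1 of the 2 values shown sits.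

Compound 3 `COc1ccc2c(c1)OC(c1cc(OC)c(OC)c(OC)c1)C(CO)=C2` carries the change hydroxymethyl in place of methoxycarbonyl on a double-bonded ring carbon relative to compound 2. The measured step concerns the carbonyl substituent and does not probe removal of the carbonyl itself, so it bears on this change only loosely. Compound 3 is expected to land near compound 2 or somewhat weaker, with the step of a 1.6-fold higher number from compound 2 to compound 3 (0.20 log units; within the scatter) not confidently beyond the scatter. The estimate for compound 3 in this assay is 22000 nM, within a range from 5000 nM to 100000 nM.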

Compound 3, half-maximal inhibitory concentration: > 50000 nM
Compound 3 gave a limit, no number (the forecaster's own chance of this, stated with the estimate: 35%); middle value at least 2.2-fold (0.35 log units) away from the limit.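

In this assay the change to hydroxymethyl gives an at least 3.6-fold higher number from compound 2 to compound 3 (0.55 log units; beyond the scatter), so replacing the whole methoxycarbonyl, and not only the group on its carbonyl carbon, moves the result beyond the scatter. For the compounds shown here, the value of compound 3 is a limit, as is that of compound 1, so the step between them cannot be read, and methoxycarbonyl remains the only group at this position with an actual number. The full size of the step from methoxycarbonyl to hydroxymethyl stays bounded: the limit of > 50000 nM in this assay, at which 2 of the 3 values shown sit.

As far as these compounds go, it remains open whether any group at this position gives a lower number than methoxycarbonyl does. A carboxylic acid, a longer ester such as ethoxycarbonyl, or an aminomethyl group would show whether the carbonyl or the methoxy part carries the difference.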